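This account rests on a few compounds, and the source may have more. Where it says the series, first, only, none or still open, it means among the compounds named here.

The series shares the core of compound 1 `Cc1cc(C(=O)Nc2ccc(-c3ccccc3S(N)(=O)=O)cc2)n(-c2cccc(N)c2)n1`. In an assay on isolated protein for inhibition of Trypsin (Homo sapiens) (a lower number here means a stronger inhibitor, a higher number a weaker inhibitor), compound 1 gives only a limit of the assay, > 1600 nM. Compound 2 `Cc1cc(C(=O)Nc2ccc(-c3ccccc3S(N)(=O)=O)cc2)n(-c2cccc(Cl)c2)n1` carries a chloro in place of an amino on an aromatic carbon, and in this assay compound 2 likewise gives only a limit, > 1600 nM. The step that the two limits leave unreadable from compound 1 to compound 2 cannot be sized, since the limit of > 1600 nM in this assay, at which 2 of the 2 values shown sit, holds both values shown. Compound 2 thus stands at the limit, with nothing measured to separate it from compound 1. Compound 3 `Cc1cc(C(=O)Nc2ccc(-c3ccccc3S(N)(=O)=O)cc2)n(-c2ccc3onc(N)c3c2)n1` differs from compound 2 by a group of 10 heavy atoms (7 carbon, 2 nitrogen, 1 oxygen; one five-membered aromatic ring with 2 hetero atoms, one six-membered aromatic ring of carbon only) in place of a group of 7 heavy atoms (6 carbon, 1 chlorine; one six-membered aromatic ring of carbon only), on an aromatic nitrogen. For the measured compounds named here, no measured step bears on this exchange, and the only step recorded sits unreadable at the limit, so neither direction nor size can be read from the measurements. Compound 3 is expected to come in near 2500 nM, within a range from 500 nM to 15000 nM. The estimated step that the limit leaves unreadable from compound 2 to compound 3 is therefore a guess rather than a forecast grounded in measured steps.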

Compound 3, inhibition constant: > 1600 nM
Compound 3 gave a limit, no number; the forecaster's own chance of this, stated with the estimate: 45%; the middle value does not contradict the limit.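

In this assay compound 3 also gives only a limit, > 1600 nM. For the compounds shown here, no new step from compound 1 or compound 2 to compound 3 can be read: the limit of > 1600 nM in this assay, at which 3 of the 3 values shown sit. The compounds shown leave open how strongly any of the three inhibits, and whether the exchanged groups differ at all in this assay.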